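Methyl for Methoxy on a Shared Benzoxazole Core, Estimated

The source may report more compounds than this note shows. Statements on the series, on what has been measured and on what is new or still open speak of the compounds shown alone.

Measured so far:
compound 1 `Cc1cccc2nc(N3CCN(C)CC3)oc12` gives 0.58
compound 2 `COc1cc(Cl)cc2nc(N3CCN(C)CC3)oc12` gives 0.62

Of the compounds shown here, two have been tested in an assay on ileum (strain Hartley) with 5-hydroxytryptamine receptor 3A (Cavia porcellus) as the target; on this read-out higher numbers stand for larger maximal responses and lower numbers for smaller maximal responses. Compound 1 shows 0.58 and compound 2 shows 0.62. Compound 2 has the higher of the two numbers, but compound 1 sits only a small way below it, a gap that lies within the usual scatter of this assay, so the two read as equal.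

Compound 3 `Cc1cc(Cl)cc2nc(N3CCN(C)CC3)oc12` has not been measured. The difference from compound 2 to compound 3 is this: methyl in place of methoxy on an aromatic carbon. Compound 3 thus combines the methyl of compound 1 with the chloro of compound 2, and both of those compounds give nearly the same response.

Among the measured compounds shown here, no measured pair isolates this change. On what compound 1 and compound 2 show, the step from compound 2 to compound 3 is expected to be a number 0.020 lower from compound 2 to compound 3 (within the scatter), that is, none beyond the scatter. Compound 3 is therefore estimated at 0.6, with a range from 0.45 to 0.75 in this assay.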

Compound 3, intrinsic activity: the largest response reached, as a fraction of the reference agonist's: 0.24
Beside the measured number, compound 3's estimate is 0.36 above it, and the stated range ends above it.
By their numbers in this assay, from the lowest: compound 3; then compounds 1 and 2 (each within the scatter of the next).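

In this assay, the position ortho to a fused ring proves sensitive to this change: with the chloro group in place, methyl for methoxy gives a number 0.38 lower from compound 2 to compound 3 (beyond the scatter), so the two groups are not interchangeable here. The chloro group also matters once methyl occupies that position, since chloro in place of hydrogen gives a number 0.34 lower from compound 1 to compound 3 (beyond the scatter), a drop that compound 2 , which carries the same chloro group alongside methoxy, does not share at this level, so the effect of each group depends on the other. Nothing available accounts for this dependence.

The compounds shown leave open whether the low response belongs to methyl with chloro specifically or would also appear with bromo or fluoro in place of chloro. They also leave open how an ethyl, ethoxy or hydroxyl group would behave at the position ortho to a fused ring.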